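This account rests on a few compounds, and the source may have more. Where it says the series, first, only, none or still open, it means among the compounds named here.

Measured in a functional assay on CAKI-1 cells (Homo sapiens) for inhibition, read by sulforhodamine B assay, with a stated time of 48 h; on this read-out higher numbers stand for weaker inhibition of growth and lower numbers for stronger inhibition of growth:
- compound 1 `O=C(Cc1csc2nc(-c3ccc(Br)cc3)cn12)N/N=C/c1ccccc1`: 30200 nM
- compound 2 `O=C(Cc1csc2nc(-c3ccc(Br)cc3)cn12)N/N=C/c1ccccc1O`: 398 nM

Compound 2 has the lower of the two numbers. Compound 3 `O=C(Cc1csc2nc(-c3ccc(Br)cc3)cn12)N/N=C/c1ccc(O)cc1` keeps the atoms but rearranges them: 4-hydroxyphenyl in place of 2-hydroxyphenyl on a carbon with a double bond to nitrogen. For the measured compounds named here, only one measured step bears on this, the large 76-fold lower number from compound 1 to compound 2 (1.88 log units; beyond the scatter), with hydroxy in place of hydrogen on an aromatic carbon. Going by the values given here, no measurement yet covers 4-hydroxyphenyl. In this assay, a step towards a higher number is therefore expected, smaller than that one. The expected value for compound 3 is 3000 nM, within an estimated range of 500 nM to 20000 nM. The estimate means a 7.5-fold higher number from compound 2 to compound 3 (0.88 log units; beyond the scatter).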

Compound 3, concentration for 50% growth inhibition: 14800 nM
For compound 3 the middle estimate is 4.9-fold (0.69 log units) below the measured one; measured number inside the range.
By their numbers in this assay, from the lowest: compound 2; then compound 3; then compound 1.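

In this assay, the same atoms joined differently give a large change (a 37-fold higher number from compound 2 to compound 3 (1.57 log units; beyond the scatter)), so the place of the hydroxy on this ring counts for far more than its mere presence. Added as 4-hydroxyphenyl, the hydroxy gives only a modest gain (a 2.0-fold lower number from compound 1 to compound 3 (0.31 log units; beyond the scatter)), and most of the gain seen with the 2-hydroxyphenyl is absent. Nothing available explains this difference between the two groups.

Still open, from the compounds shown here alone, is whether a methoxy or an amine in place of the hydroxy on the 2-hydroxyphenyl would keep the low number of compound 2.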